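The source may report more compounds than this note shows. Statements on the series, on what has been measured and on what is new or still open speak of the compounds shown alone.

In a functional assay on HOS cells (Homo sapiens) for antiproliferative activity, read by sulforhodamine B assay (on this read-out higher numbers stand for weaker inhibition of growth and lower numbers for stronger inhibition of growth), compound 3 (`C[C@@H]1O[C@H](COCc2ccccc2)[C@@H](OCc2ccccc2)[C@H](OCc2ccccc2)C1=O`) gives > 50000 nM, which is a limit of the assay and not a number. Its true value is therefore unknown, and it cannot be placed exactly against its relatives. Compound 1 (`CCC[C@H]1O[C@H](COCc2ccccc2)[C@@H](OCc2ccccc2)[C@H](OCc2ccccc2)[C@H]1O`) gives 23600 nM. Compound 2 (`O[C@@H]1[C@@H](OCc2ccccc2)[C@H](OCc2ccccc2)[C@@H](COCc2ccccc2)O[C@@H]1CC1CCCCC1`) gives <= 20700 nM, which is also a limit. Among the measured compounds shown here, the one measured step, an at least 1.1-fold lower number from compound 1 to compound 2 (0.05 log units; that floor lies within the scatter), has a floor within the usual scatter, so it shows no firm effect of changing that side group.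

Compound 4 (`CCCCC[C@@H]1O[C@H](COCc2ccccc2)[C@@H](OCc2ccccc2)[C@H](OCc2ccccc2)C1=O`) differs from compound 3 by butyl in place of hydrogen on a saturated chain carbon bound to a saturated ring carbon. The same difference can be read as methyl to pentyl. For the measured compounds named here, no measured step matches this change directly, since compound 1 and compound 2 also differ from compound 3 elsewhere in the structure. The closest guide is compound 1 at 23600 nM, a relative with a longer chain than compound 3 that still gives a number. A modest shift towards stronger growth inhibition is therefore expected, and the estimated step is an at least 1.7-fold lower number from compound 3 to compound 4 (0.25 log units; that floor lies within the scatter). For compound 4 the expected value is 28000 nM, with an estimated range from 11000 nM to 70000 nM.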

Compound 4, concentration for 50% growth inhibition: > 50000 nM
Compound 4: only a limit was reported; the forecaster's own chance of this, stated with the estimate: 35%; middle value at least 1.7-fold (0.25 log units) from the limit.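

In this assay, compound 3 and compound 4 both give only a limit of the assay and not a number, so no step can be read between them. The compounds shown leave open whether butyl in place of hydrogen on a saturated chain carbon bound to a saturated ring carbon changes growth inhibition at all.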